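The compounds below may be only part of what the source reports. "The series", "measured", "known", "first", "only" and "open" are said of these compounds alone.

Compound 1 `COc1ccc2nc(C)cc(NCc3ccncc3)c2c1`: 40900 nM
Compound 2 `COc1ccc2nc(C)cc(SCc3ccccc3)c2c1`: 30600 nM

In a functional assay on MCF-10A cells (Homo sapiens) for antiproliferative activity, with a stated time of 48 h (on this read-out lower numbers stand for an effect already at smaller amounts and higher numbers for an effect only at larger amounts of compound), compound 1 gives 40900 nM and compound 2 gives 30600 nM. These two values lie within the usual scatter of each other, so compound 1 does not stand apart.

Compound 3 `COc1ccc2nc(C)cc(NCc3ccc(C)cc3)c2c1` keeps the core of compound 1 but carries 4-methylphenyl in place of pyridin-4-yl on a saturated chain carbon bound to a nitrogen on an aromatic ring.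

Within the data shown here, no measured pair shows this change, so only a modest move toward a lower number is expected. The estimated step of a 1.4-fold lower number from compound 1 to compound 3 (0.13 log units; within the scatter) stays within the scatter. For compound 3 the expected value is 30000 nM, with an estimated range of 12000 nM to 75000 nM.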

Compound 3, half-maximal effective concentration: 18800 nM
Compound 3: middle estimate off by 1.6-fold (0.20 log units), on the high side; the range from low to high includes it.
By their numbers in this assay, from the lowest: compounds 3, 2 and 1 (each within the scatter of the next, the first and the last beyond it).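

Among these compounds, replacing pyridin-4-yl with 4-methylphenyl on a saturated chain carbon bound to a nitrogen on an aromatic ring gives the first step here that clears the usual scatter in this assay (a 2.2-fold lower number from compound 1 to compound 3 (0.34 log units; beyond the scatter)). The number at this position therefore responds to the group it carries, although the step is modest. Nothing available here explains the step.

The change removes a ring nitrogen and adds a methyl together, so a plain phenyl group would be needed to tell the two apart. From the compounds shown here alone, how a carboxylic acid on that ring would read also remains open.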